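The source may report more compounds than this note shows. Statements on the series, on what has been measured and on what is new or still open speak of the compounds shown alone.

Measured in an ADME assay on Huh-5-2 cells (Homo sapiens) for cytotoxicity, read by WST assay, with a stated time of 3 days; a lower number here means that less compound is tolerated, a higher number that more compound is tolerated:
compound 1, `N#Cc1ccccc1COc1cc(O)c2c(=O)c(O)c(-c3ccccc3)oc2c1` — compound 1 gives 22000 nM
compound 2, `Cc1ccccc1COc1cc(O)c2c(=O)c(O)c(-c3ccccc3)oc2c1` — compound 2 gives 17000 nM
compound 3, `O=c1c(O)c(-c2ccccc2)oc2cc(OCc3cccc(Br)c3)cc(O)c12` — compound 3 reaches only the limit of > 100000 nM, a limit of this assay and not a number

Compound 3 thus stands at the top of the three values, known only as a limit (the limit of > 100000 nM in this assay, at which 1 of the 3 values shown sits).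

Compound 4, `N#Cc1cccc(COc2cc(O)c3c(=O)c(O)c(-c4ccccc4)oc3c2)c1`, has not yet been measured. It differs from compound 3 by cyano in place of bromo on an aromatic carbon.

Within the data shown here, two measured steps bear on this change. The step of an at least 4.5-fold higher number from compound 1 to compound 3 (0.65 log units; beyond the scatter) and the step of an at least 5.8-fold higher number from compound 2 to compound 3 (0.76 log units; beyond the scatter) both move from a 2-substituted benzyl to the 3-bromobenzyl and both read at least modest. The step of a 1.3-fold lower number from compound 1 to compound 2 (0.11 log units; within the scatter), cyano against methyl on the same ring, lies within the scatter, so the two 2-substituents behave alike. Among the measured compounds shown here, whether the gain in compound 3 comes from the bromo itself or from its place on the ring cannot be separated with these three compounds; no step swaps a substituent at the 3-position. A step of moderate size downward, or none beyond the scatter, is therefore expected for compound 4, written as an at least 2.0-fold lower number from compound 3 to compound 4 (0.30 log units; that floor lies within the scatter).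

Compound 4 is estimated at 50000 nM, with a range from 15000 nM to 200000 nM.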

Compound 4, half-maximal cytotoxic concentration: 72000 nM
The estimate for compound 4 lay 1.4-fold (0.16 log units) below the measured number, and the stated range covers the measured number.
By their numbers in this assay, from the lowest: compounds 2 and 1 (each within the scatter of the next); then compound 4. At a limit, above all of these: compound 3.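

In this assay, the change of bromo to cyano on this aromatic carbon gives an at least 1.3-fold lower number from compound 3 to compound 4 (0.14 log units; that floor lies within the scatter), so the real size of this step remains unresolved. Compound 3 is known only as a limit of the assay: the limit of > 100000 nM in this assay, at which 1 of the 4 values shown sits. The earlier compounds shown here could not separate substituent from place, but a 3.3-fold higher number from compound 1 to compound 4 (0.51 log units; beyond the scatter) keeps the cyano group and changes only its place, while a 4.2-fold higher number from compound 2 to compound 4 (0.63 log units; beyond the scatter) gives a step of similar reading against the 2-methylphenyl compound, so in these four compounds both 3-substituted benzyl groups stand above both 2-substituted ones, with none going against this.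

Still open, on these data alone, is how much bromo and cyano really differ in this place. Also open, as far as these compounds go, is whether a methyl group, an amine or a carboxylic acid there would keep the number as high as in compound 4.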